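The source may hold more compounds than are shown below. What is called first, only, known or untested is meant among the compounds shown, and "the series" means these compounds.

Series notes, sodium/hydrogen exchanger. In a functional assay for inhibition of sodium/hydrogen exchanger (Oryctolagus cuniculus) (on this read-out higher numbers stand for weaker inhibition and lower numbers for stronger inhibition), compound 1 `CCc1cc(C)c(C(=O)N=C(N)N)cc1S(C)(=O)=O` gives 4.8 nM, compound 2 `COc1cc(C)c(C(=O)N=C(N)N)cc1S(C)(=O)=O` gives 16 nM and compound 3 `Cc1cc(Oc2ccc(Cl)cc2)c(S(C)(=O)=O)cc1C(=O)N=C(N)N` gives 13 nM. Compound 3 stands second highest of the three numbers: its value and that of compound 2 lie within the scatter of each other, while compound 1 sits beyond it. The two substitutions at the same aromatic carbon were a 3.3-fold higher number from compound 1 to compound 2 (0.52 log units; beyond the scatter) and a 2.7-fold higher number from compound 1 to compound 3 (0.43 log units; beyond the scatter); replacing the group on the oxygen gave a 1.2-fold lower number from compound 2 to compound 3 (0.09 log units; within the scatter). Compound 4 `Cc1cc(Nc2ncccn2)c(S(C)(=O)=O)cc1C(=O)N=C(N)N` differs from compound 3 by (pyrimidin-2-yl)amino in place of 4-chlorophenoxy on an aromatic carbon. Changes at this carbon have so far stayed modest, so for this assay no step beyond the scatter is expected, a 1.2-fold higher number from compound 3 to compound 4 (0.06 log units; within the scatter). Compound 4 is estimated at 15 nM, range 5 nM to 45 nM.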

Compound 4, half-maximal inhibitory concentration: 8.3 nM
Estimate against measurement, compound 4: 1.8-fold (0.26 log units) above; the range from low to high includes it.
By their numbers in this assay, from the lowest: compounds 1, 4, 3 and 2 (each within the scatter of the next, the first and the last beyond it).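

At this aromatic carbon, ortho to a methylsulfonyl group, (pyrimidin-2-yl)amino in place of 4-chlorophenoxy gives a 1.6-fold lower number from compound 3 to compound 4 (0.19 log units; within the scatter), in place of methoxy a 1.9-fold lower number from compound 2 to compound 4 (0.29 log units; within the scatter) and in place of ethyl a 1.7-fold higher number from compound 1 to compound 4 (0.24 log units; within the scatter). The position thus takes a group with a hydrogen-bond donor and a ring with two hetero atoms, with no step beyond the scatter against any earlier compound. Nothing at hand explains these steps.

Open, as far as these compounds go, is whether phenylamino would read the same as (pyrimidin-2-yl)amino. Also open, from the compounds shown here alone, is how a piperidine or a carboxylic acid at this carbon would read.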